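A nitro-bearing chlorophenyl replaces the chlorophenyl of compound 2

The source may hold more compounds than are shown below. What is called first, only, known or untested is meant among the compounds shown, and "the series" means these compounds.

For the measured compounds named here, compound 2 `N#CC1=C(N)Oc2c(N)cc3nc4ccccc4nc3c2C12C(=O)N(Cc1cnnn1-c1ccccc1Cl)c1ccccc12` is the only compound with a number in a functional assay on HepG2 cells (Homo sapiens) for antiproliferative activity, read by MTT assay, with a stated time of 48 h (a higher number here means a weaker inhibitor, a lower number a stronger inhibitor), where compound 2 gives 33500 nM. Compound 1 `CC(=O)Nc1ccc(-n2nncc2CN2C(=O)C3(C(C#N)=C(N)Oc4c3c3nc5ccccc5nc3c3ccccc43)c3ccccc32)cc1` reaches only a limit there, > 50000 nM, namely (the limit of > 50000 nM in this assay, at which 1 of the 2 values shown sits). Compound 3 `N#CC1=C(N)Oc2c(N)cc3nc4ccccc4nc3c2C12C(=O)N(Cc1cnnn1-c1ccc(Cl)cc1[N+](=O)[O-])c1ccccc12` differs from compound 2 by 4-chloro-2-nitrophenyl in place of 2-chlorophenyl on an aromatic nitrogen. Going by the values given here, no measured pair shows this change, so no step beyond the usual scatter is foreseen in either direction. Compound 3 is therefore estimated at 30000 nM, within a range of 12000 nM to 70000 nM. The expected step of a 1.1-fold lower number from compound 2 to compound 3 (0.05 log units; within the scatter) is thought to stay within the scatter.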

Compound 3, half-maximal inhibitory concentration: > 50000 nM
Compound 3: no number, only a limit; the forecaster's own chance of this, stated with the estimate: 30%; middle value at least 1.6-fold (0.22 log units) away from the limit.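

In this assay, for the compounds shown here, the swap of 2-chlorophenyl for 4-chloro-2-nitrophenyl on the aromatic nitrogen gives an at least 1.4-fold higher number from compound 2 to compound 3 (0.17 log units; that floor lies within the scatter) and so provides the first step at this position. The value of compound 3 is a limit, > 50000 nM as printed, so the true size of the step cannot be read, but the change does not lower the number. Compound 3 thus sits with compound 1 at that limit: the limit of > 50000 nM in this assay, at which 2 of the 3 values shown sit.

Left open is whether an amine or a carboxylic acid on this phenyl ring would bring the number below that of compound 2.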